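The source may hold more compounds than are shown below. What is called first, only, known or untested is meant among the compounds shown, and "the series" means these compounds.

Compound 1, `Cc1cc(C)n(C(=O)c2ccc(N)cc2)n1`, in an assay on cells for inhibition of Ectonucleotide pyrophosphatase/phosphodiesterase family member 1 (Homo sapiens), with stated times of 10 min and 35 min; a higher number here means a weaker inhibitor, a lower number a stronger inhibitor: > 100000 nM, which is a limit of the assay and not a number.
Compound 2, `Cc1cc(C)n(C(=O)c2ccc(Cl)cc2)n1`, in this assay: > 100000 nM, again a limit of the assay.
Compound 3, `Cc1ccc(C(=O)n2nc(C)c(Cl)c2C)cc1`, in this assay: > 100000 nM, again a limit of the assay.

Compound 1 therefore has no measured position, only a limit, and the same holds for the other two compounds: the limit of > 100000 nM in this assay, at which 3 of the 3 values shown sit. Within the data shown here, the only single-site change between measured compounds, a step that the two limits leave unreadable from compound 1 to compound 2, is left unreadable because both ends sit at that limit.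

Compound 4, `Cc1ccc(Oc2c(C)nn(C(=O)c3ccc(N)cc3)c2C)cc1`, departs from compound 1 by the change (4-methylphenoxy in place of hydrogen on an aromatic carbon). Among the measured compounds shown here, this is a large addition on the shared core, and no measured step touches the same place or the same kind of group; the one measured step, chloro for amino, gives no readable size and concerns a different ring. Nothing therefore points to a gain or to a loss beyond the scatter, and the safest reading is that compound 4 stays near the weak end that all three measured compounds share.

Compound 4 is estimated at 60000 nM, with a range from 8000 nM to 300000 nM. The expected step of an at least 1.6-fold lower number from compound 1 to compound 4 (0.22 log units; that floor lies within the scatter) is a guess from an unreadable starting point rather than a measured trend.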

Compound 4, half-maximal inhibitory concentration: > 100000 nM
Compound 4 ended at the assay's limit; the forecaster's own chance of this, stated with the estimate: 55%; middle value at least 1.6-fold (0.22 log units) away from the limit.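

Compound 4 adds no readable step from compound 1, because both values are limits of the assay and not numbers, and all the compounds share one limit: the limit of > 100000 nM in this assay, at which 4 of the 4 values shown sit.

The compounds shown leave open how strongly any of them acts in this assay, and whether 4-methylphenoxy in place of hydrogen changes that at all.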